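Notes on the series: compound 2 to compound 3

The source may report more compounds than this note shows. Statements on the series, on what has been measured and on what is new or still open speak of the compounds shown alone.

In an ADME assay on RAW264.7 cells (Mus musculus) for cytotoxicity, read by MTT assay, with a stated time of 24 h, in the absence of a further agent (a lower number here means a stronger inhibitor, a higher number a weaker inhibitor), compound 1 (`COCCCOc1ccc(C(O)C2OC(=O)c3c(OC)cc(OC)cc32)cc1`) gives > 40000 nM as a limit, not a number. Compound 2 (`COc1cc(OC)c2c(c1)C(C(O)c1ccc(OCCOc3ccccc3)cc1)OC2=O`) gives > 40000 nM and this too is only a limit. Compound 2 therefore has no number of its own and stands at the shared limit (the limit of > 40000 nM in this assay, at which 2 of the 2 values shown sit).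

Compound 3 (`COc1cc(OC)c2c(c1)C(C(O)c1ccc(OCc3ccc(F)cc3)cc1)OC2=O`) follows through 4-fluorophenyl in place of phenoxymethyl on a saturated chain carbon bound to an oxygen on an aromatic ring and reads, cut one bond further out, as 2-phenoxyethoxy to (4-fluorobenzyl)oxy. For the measured compounds named here, one measured step bears on this change (a step that the two limits leave unreadable from compound 1 to compound 2), and it has no readable size, so it gives no direction. The step expected in this assay is none beyond the scatter, and compound 3 is expected to report a limit again. The estimated step (a number no higher from compound 2 to compound 3 (the limit leaves the size open)) carries no expected direction. The estimate for compound 3 is 40000 nM (expected range 15000 nM to 80000 nM).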

Compound 3, half-maximal inhibitory concentration: > 40000 nM
Compound 3 was reported as a limit (the forecaster's own chance of this, stated with the estimate: 75%); the middle value lies on the limit itself.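

In this assay compound 3 gives > 40000 nM, a limit and not a number. For the compounds shown here, no step among compound 1, compound 2 and compound 3 can be read. The compounds shown leave open whether 2-phenoxyethoxy and (4-fluorobenzyl)oxy differ at all, since every value rests on one limit: the limit of > 40000 nM in this assay, at which 3 of the 3 values shown sit.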